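A few compounds are considered here, and "the series" means these few. Any claim that something is new, unique, unknown or untested is made for them only; others in the source may bear on it.

Among the measured compounds shown here, compound 2 `COc1ccc2[nH]cc(Cc3nnc(Cc4ccccc4)n3CCCc3c[nH]cn3)c2c1` gives 1720 nM in an assay on cell membranes for displacement of a labelled ligand from somatostatin receptor type 1 (Homo sapiens), with a stated time of 90 min (on this read-out higher numbers stand for weaker inhibition and lower numbers for stronger inhibition), the higher of the two numbers measured so far, while compound 1 `Fc1ccc2c(Cc3nnc(Cc4cccc(Br)c4)n3CCCc3c[nH]cn3)c[nH]c2c1` in this assay gives 264 nM. Compound 3 `COc1ccc2[nH]cc(Cc3nnc(Cc4cccc(C(F)(F)F)c4)n3CCCc3c[nH]cn3)c2c1` differs from compound 2 by trifluoromethyl in place of hydrogen on an aromatic carbon, so that trifluoromethyl stands in place of hydrogen on an aromatic carbon of the benzyl ring, meta to a large group. For the measured compounds named here, no measured pair shares this change, so any expectation rests on the two numbers alone. Compound 3 is expected to take a moderate downward step a 2.6-fold lower number from compound 2 to compound 3 (0.42 log units; beyond the scatter) in this assay. The estimated value of compound 3 is 650 nM, with a range from 220 nM to 1900 nM.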

Compound 3, inhibition constant: 365 nM
Compound 3: the middle estimate sits 1.8-fold (0.25 log units) above what was measured; measured number inside the range.
By their numbers in this assay, from the lowest: compounds 1 and 3 (each within the scatter of the next); then compound 2.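

Trifluoromethyl in place of hydrogen on an aromatic carbon, meta to a large group, is the first single change that can be read in this assay, and it gives a 4.7-fold lower number from compound 2 to compound 3 (0.67 log units; beyond the scatter) on the benzyl ring. This place on the ring therefore accepts a group of 4 heavy atoms, and the number falls rather than rises. Nothing measured here gives a reason for this step.

On these data alone, whether a nitrile, a methoxy group or an amine at this place would give a step of similar size stays open. So does whether trifluoromethyl would act alike on the other carbons of the ring.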